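Carbamoyl in place of the tetrazolyl group of compound 3

This account rests on a few compounds, and the source may have more. Where it says the series, first, only, none or still open, it means among the compounds named here.

In an ADME assay on HEp-2 cells (Homo sapiens) for cytotoxicity (a lower number here means that less compound is tolerated, a higher number that more compound is tolerated), compound 1 (`CC(C)CCn1c(Cn2c(=O)n(C(C)C)c3ccccc32)nc2cc(CNC3CC3)ccc21`) gives 17200 nM and compound 2 (`CC(C)CCn1c(Cn2c(=O)n(C(C)C)c3ccccc32)nc2cc(Br)ccc21`) gives 18100 nM, which is a 1.1-fold higher number from compound 1 to compound 2 (0.02 log units; within the scatter). Compound 3 (`CC(C)CCn1c(Cn2c(=O)n(C(C)C)c3ccccc32)nc2cc(-c3nn[nH]n3)ccc21`) stands lowest of the three at 2000 nM. The two steps to it are an 8.6-fold lower number from compound 1 to compound 3 (0.93 log units; beyond the scatter) and a 9.1-fold lower number from compound 2 to compound 3 (0.96 log units; beyond the scatter). Compound 4 (`CC(C)CCn1c(Cn2c(=O)n(C(C)C)c3ccccc32)nc2cc(C(N)=O)ccc21`) carries carbamoyl in place of 2H-tetrazol-5-yl on an aromatic carbon. Those two steps bear most directly on this change, as both remove or add the same group. From the compounds shown here alone, with the tetrazolyl group gone, most of that distance is expected to be recovered, though carbamoyl itself is untested. The estimated step, toward a higher number, is a 5.5-fold higher number from compound 3 to compound 4 (0.74 log units; beyond the scatter). Compound 4 is estimated at 11000 nM, with an expected range of 4000 nM to 30000 nM.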

Compound 4, half-maximal cytotoxic concentration: 23400 nM
The estimate for compound 4 lay 2.1-fold (0.33 log units) below the measured number; the range from low to high includes it.
By their numbers in this assay, from the lowest: compound 3; then compounds 1, 2 and 4 (each within the scatter of the next).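

In this assay carbamoyl in place of 2H-tetrazol-5-yl gives a 12-fold higher number from compound 3 to compound 4 (1.07 log units; beyond the scatter) although each group carries one hydrogen-bond donor, so that count does not go with the low number. Against bromo and (cyclopropylamino)methyl, carbamoyl gives a 1.3-fold higher number from compound 2 to compound 4 (0.11 log units; within the scatter) and a 1.4-fold higher number from compound 1 to compound 4 (0.13 log units; within the scatter), leaving 2H-tetrazol-5-yl as the only one of the four groups at this position that stands apart. Nothing shown explains what sets the tetrazolyl group apart. From the compounds shown here alone, whether a carboxylic acid or another five-membered aromatic ring on this carbon would also give a low number remains open.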